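Replacing 2-fluorophenyl with 3-methoxyphenyl on a shared core

A few compounds are considered here, and "the series" means these few. Any claim that something is new, unique, unknown or untested is made for them only; others in the source may bear on it.

Of the compounds shown here, three built on one core have so far been measured in a functional assay on cells (Cancer cell lines, Homo sapiens) for inhibition, read by MTT assay, with a stated time of 48 h; a higher number here means a weaker inhibitor, a lower number a stronger inhibitor. Compound 1 (`O=C(/C=C/c1cccc(Br)c1)NNC(=O)c1ccc2c(c1)OCCO2`) gives 3330 nM, compound 2 (`O=C(/C=C/c1ccccc1)NNC(=O)c1ccc2c(c1)OCCO2`) gives 550 nM, and compound 3 (`O=C(/C=C/c1ccccc1F)NNC(=O)c1ccc2c(c1)OCCO2`) gives 4510 nM. Compound 3 therefore sits level with compound 1, while compound 2 is the strongest of the three. Both gaps to compound 2 are clear: a 6.1-fold lower number from compound 1 to compound 2 (0.78 log units; beyond the scatter) when hydrogen replaces bromo, and an 8.2-fold higher number from compound 2 to compound 3 (0.91 log units; beyond the scatter) when fluoro replaces hydrogen.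

The next compound, compound 4 (`COc1cccc(/C=C/C(=O)NNC(=O)c2ccc3c(c2)OCCO3)c1`), has 3-methoxyphenyl in place of 2-fluorophenyl on a double-bonded chain carbon bound to a double-bonded chain carbon. Among the measured compounds shown here, no measurement yet shows what a 3-methoxyphenyl group does here. The closest guide is an exchange of one substituted group for another at this same place, which gives a 1.4-fold higher number from compound 1 to compound 3 (0.13 log units; within the scatter) and stays within the scatter. The two larger steps suggest that a return towards compound 2 is possible, but only a slight lean in that direction seems justified. The expected change is a 1.8-fold lower number from compound 3 to compound 4 (0.26 log units; within the scatter), which is no step beyond the scatter. Compound 4 is estimated at 2500 nM, with an expected range from 700 nM to 7500 nM.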

Compound 4, half-maximal inhibitory concentration: 170 nM
Estimate against measurement, compound 4: 15-fold (1.17 log units) above; measured number below the stated range.
By their numbers in this assay, from the lowest: compound 4; then compound 2; then compounds 1 and 3 (each within the scatter of the next).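

In this assay, a group on this ring does not have to weaken the compound: with methoxy in place of hydrogen there is a 3.2-fold lower number from compound 2 to compound 4 (0.51 log units; beyond the scatter), whereas the bromo and fluoro compounds both had higher numbers than compound 2. The identity of the group matters as well as its presence, as methoxy in place of bromo gives a 20-fold lower number from compound 1 to compound 4 (1.29 log units; beyond the scatter), and the exchange of 2-fluorophenyl for 3-methoxyphenyl gives a 27-fold lower number from compound 3 to compound 4 (1.42 log units; beyond the scatter), a far larger change than the earlier exchange of one substituted ring for another. No measurement available here explains why these groups differ so sharply.

The exchange between compound 3 and compound 4 alters both the substituent and its number on the ring, so the compounds shown cannot divide that large step between the two changes. As far as these compounds go, it also remains open whether the oxygen of the methoxy group matters, which an ethyl group could test, and whether a longer chain such as ethoxy, or an amine, would keep or lose the low number of compound 4.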